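Flipping the ring stereocentre of a chromanone scaffold

The source may hold more compounds than are shown below. What is called first, only, known or untested is meant among the compounds shown, and "the series" means these compounds.

Measured so far:
- compound 1 `Cc1ccc2c(c1)O[C@H](c1ccccc1)CC2=O` gives 110 nM
- compound 2 `Cc1ccc2c(c1)OC(c1ccccc1)CC2=O` gives 3620 nM

Compound 2 stands highest of the two numbers recorded in an in vitro assay on BTI-TN-5B1-4 cells for inhibition of Amine oxidase [flavin-containing] B (Homo sapiens); on this read-out lower numbers stand for stronger inhibition and higher numbers for weaker inhibition; its nearest neighbour is compound 1, which gives a 33-fold higher number from compound 1 to compound 2 (1.52 log units; beyond the scatter) step when read from compound 1 to compound 2, the only structural difference being that the stereocentre at a saturated ring carbon is drawn S in compound 1 and without a configuration in compound 2. That step is large and may be connected to the fact that one of compounds 1 and 2 is drawn with a defined configuration and the other without, at the place where they differ.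

Compound 3 `Cc1ccc2c(c1)O[C@@H](c1ccccc1)CC2=O` has not yet been measured. It differs from compound 2 as follows: the two compounds have the same atoms and bonds; at least one stereo element is drawn with a configuration in one of them and without one in the other: 1 of 1 stereo elements differ; a stereocentre at a saturated ring carbon is drawn without a configuration in compound 2 and R in compound 3. Going by the values given here, the one measured step shows that fixing this stereocentre as S gives a far lower number than leaving it undefined. Compound 3 carries the opposite configuration, so the expected move is in the other direction: the number for compound 3 is estimated to be higher again, a step of a 2.8-fold higher number from compound 2 to compound 3 (0.44 log units; beyond the scatter) in this assay. The estimate for compound 3 is therefore 10000 nM, with a range from 2000 nM to 50000 nM.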

Compound 3, half-maximal inhibitory concentration: 140 nM
The estimate for compound 3 lay 71-fold (1.85 log units) above the measured number, outside the stated range (below it).
By their numbers in this assay, from the lowest: compounds 1 and 3 (each within the scatter of the next); then compound 2.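

The two drawn configurations at this saturated ring carbon cannot be told apart in this assay, since the step between them reads a 1.3-fold higher number from compound 1 to compound 3 (0.10 log units; within the scatter), and the single change behind that step is this: the fact that compounds 1 and 3 differ only in the configuration as drawn

The compound that stands apart is therefore the one with no drawn configuration, with a 26-fold lower number from compound 2 to compound 3 (1.41 log units; beyond the scatter), a move opposite in direction to a 33-fold higher number from compound 1 to compound 2 (1.52 log units; beyond the scatter), so the earlier step was no sign of a preference for S, and both large steps coincide with this difference in drawing: the fact that one of compounds 2 and 3 is drawn with a defined configuration and the other without, at the place where they differ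

Two forms with matching numbers would not by themselves lead to a much higher number for a sample drawn without a configuration, so the drawing alone does not account for the value of compound 2.

The compounds shown leave open what the sample of compound 2 actually contains, and so what lies behind its higher number. They also leave open whether configuration at this carbon stays this unimportant when an amine or a carboxylic acid takes the place of the phenyl group.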